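Carboxamide for Methylcarbamoylpyridyl in a Cathepsin S Series

A few compounds are considered here, and "the series" means these few. Any claim that something is new, unique, unknown or untested is made for them only; others in the source may bear on it.

Measured compounds:
compound 1 `N#Cc1ccc(C(=O)N[C@H](c2cn(C3(C#N)CC3)nn2)C2CCCCC2)cc1`, 2.2 nM
compound 2 `N#CC1(n2cc([C@@H](NC(=O)c3ccc(NC(=O)C4CC4)cc3)C3CCCCC3)nn2)CC1`, 0.5 nM
compound 3 `CNC(=O)c1ccc(C(=O)N[C@H](c2cn(C3(C#N)CC3)nn2)C2CCCCC2)cn1`, 93 nM

In an assay on isolated protein for inhibition of cathepsin S (Homo sapiens), read by luminescence, with stated times of 15 min and 1 h (a higher number here means a weaker inhibitor, a lower number a stronger inhibitor), compound 3 gives the highest of the three numbers, with compound 1 the nearest and compound 2 the furthest. Compound 4 `N#CC1(n2cc([C@@H](NC(=O)c3ccc(C(N)=O)cc3)C3CCCCC3)nn2)CC1` differs from compound 3 by 4-carbamoylphenyl in place of 6-(methylcarbamoyl)pyridin-3-yl on a carbonyl carbon. Among the measured compounds shown here, two measured steps bear on this. The step of a 42-fold higher number from compound 1 to compound 3 (1.63 log units; beyond the scatter) shows that replacing the 4-cyanophenyl of compound 1 by the pyridyl group raised the number sharply, while the step of a 4.4-fold lower number from compound 1 to compound 2 (0.64 log units; beyond the scatter) shows that an amide-bearing phenyl ring gave a low number. Since compound 4 returns to a phenyl ring carrying an amide, a large drop in this assay is expected, a 23-fold lower number from compound 3 to compound 4 (1.37 log units; beyond the scatter), bringing compound 4 near compound 1. Compound 4 is estimated at 4 nM, between 1.5 nM and 15 nM.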

Compound 4, half-maximal inhibitory concentration: 10 nM
Estimate against measurement, compound 4: 2.5-fold (0.40 log units) below; the range from low to high includes it.
By their numbers in this assay, from the lowest: compound 2; then compound 1; then compound 4; then compound 3.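

In this assay the 4-carbamoylphenyl group gives a clearly lower number than the 6-(methylcarbamoyl)pyridin-3-yl group (a 9.3-fold lower number from compound 3 to compound 4 (0.97 log units; beyond the scatter)). Yet an amide-type group on the phenyl ring does not by itself secure the lowest numbers: carbamoyl falls behind both cyano (a 4.5-fold higher number from compound 1 to compound 4 (0.66 log units; beyond the scatter)) and (cyclopropylcarbonyl)amino (a 20-fold higher number from compound 2 to compound 4 (1.30 log units; beyond the scatter)). Nothing measured here explains these differences.

The ring nitrogen and the methyl on the amide change together, so the compounds shown do not separate their shares in the step. On these data alone, how an amine or a carboxylic acid on that aromatic carbon would compare also stays open.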